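The source may hold more compounds than are shown below. What is called first, only, known or untested is meant among the compounds shown, and "the series" means these compounds.

The series shares one core and varies the group on a saturated chain carbon bound to an oxygen on an aromatic ring. In a functional assay on RAW264.7 cells (Mus musculus) for inhibition, read by immunoassay, with a stated time of 12 h, tested at 30 uM (a higher number here means more inhibition at the concentration tested (going by the name of the read-out), a lower number less inhibition), compound 1 `CC(C)=CCOc1ccccc1C1CC(=O)c2ccccc2O1` gives 41.8%, compound 2 `COCOc1ccccc1C1CC(=O)c2ccccc2O1` gives 35.2%, and compound 3 `CCOc1ccccc1C1CC(=O)c2ccccc2O1` gives 29.6%. Compound 2 stands second highest of the three numbers; the steps of a number 6.6 percentage points lower from compound 1 to compound 2 (within the scatter) and a number 5.6 percentage points lower from compound 2 to compound 3 (within the scatter) lie within the scatter, while a number 12.2 percentage points lower from compound 1 to compound 3 (beyond the scatter) is beyond it. Compound 4 `CCCCOc1ccccc1C1CC(=O)c2ccccc2O1` carries propyl in place of methoxy on a saturated chain carbon bound to an oxygen on an aromatic ring. The two steps that touch compound 2 bear on this change and both were small, so in this assay no step beyond the scatter is expected, at most a slight rise. The expected step is a number 2.8 percentage points higher from compound 2 to compound 4 (within the scatter). Compound 4 is therefore estimated at 38%, between 27% and 49%.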

Compound 4, a percentage reported as inhibition, at one concentration (the size of the read-out at that concentration, not a potency): 19.3%
Compound 4: the middle estimate sits 18.7 percentage points above what was measured; measured number below the stated range.
By their numbers in this assay, from the lowest: compound 4; then compounds 3, 2 and 1 (each within the scatter of the next, the first and the last beyond it).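

In this assay this position proves sensitive to the change, and compound 4 falls beyond the scatter from every other compound shown (a number 15.9 percentage points lower from compound 2 to compound 4 (beyond the scatter); a number 10.3 percentage points lower from compound 3 to compound 4 (beyond the scatter); a number 22.5 percentage points lower from compound 1 to compound 4 (beyond the scatter)). Extending the saturated chain lowers the number here, but compound 1, with 2-methylprop-1-en-1-yl at the same place, does not share that drop, so group size alone does not order the series. Nothing measured accounts for the drop.

Still open, as far as these compounds go, is whether a longer saturated chain such as hexyl lowers the number further. From the compounds shown here alone, how an amine or a carboxylic acid on this chain would read also remains open.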